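The source may report more compounds than this note shows. Statements on the series, on what has been measured and on what is new or still open speak of the compounds shown alone.

Measured in a functional assay on MCF7 cells (Homo sapiens) for antiproliferative activity, read by MTT assay, with a stated time of 72 h; a higher number here means a weaker inhibitor, a lower number a stronger inhibitor:
- Compound 1 `CCCCCCCCCCNC[C@@H]1OC[C@H](N)[C@@H]1O`: 34200 nM
- Compound 2 `CCCCCCCCCCCCCCNC[C@@H]1OC[C@H](N)[C@H]1O`: 8830 nM

Compound 2 gives the lower of these two numbers, and its gap to compound 1 lies beyond the usual scatter. Among the measured compounds shown here, with only two compounds measured, this places compound 2 ahead of one neighbour and says little more.

The next compound to be tested is compound 3 `CCCCCCCCCCCCCCNC[C@@H]1OC[C@H](N)[C@@H]1O`. It has the same atoms and bonds as compound 2, and nothing leaves or enters. The change is the two compounds have the same atoms and bonds and differ only in configuration as drawn: 1 of 3 stereo elements differ; a stereocentre at a saturated ring carbon is drawn R in compound 2 and S in compound 3: a stereocentre at a saturated ring carbon is drawn R in compound 2 and S in compound 3.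

For the measured compounds named here, no pair of measured compounds shows this change alone, so the data give no direct guide to its size or direction. With nothing pointing either way, no step beyond the scatter is expected in this assay. The estimated change is a 1.1-fold lower number from compound 2 to compound 3 (0.04 log units; within the scatter), which is expected to remain within the scatter. The estimate for compound 3 is 8000 nM, with an expected range of 3500 nM to 18000 nM.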

Compound 3, half-maximal inhibitory concentration: 720 nM
For compound 3 the middle estimate is 11-fold (1.05 log units) above the measured one; measured number outside the range, below it.
By their numbers in this assay, from the lowest: compound 3; then compound 2; then compound 1.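

In this assay, the configuration at this saturated ring carbon proves to weigh heavily on the read-out, with S as drawn in place of R giving a 12-fold lower number from compound 2 to compound 3 (1.09 log units; beyond the scatter). The step can be laid to that stereocentre alone, because no atom leaves or enters: the fact that compounds 2 and 3 differ only in the configuration as drawn. With the S configuration held, the chain can now be read as well: butyl in place of hydrogen on a saturated chain carbon goes with a 48-fold lower number from compound 1 to compound 3 (1.68 log units; beyond the scatter), which the earlier pair could not show, as compound 1 and compound 2 differ in both chain and configuration.

The compounds shown leave open whether the same inversion would give a step of similar size with the shorter chain of compound 1, and whether the other two stereo elements weigh as much as this one. They also leave open how a longer chain, or a phenyl group in place of the chain, would read in this assay.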